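Phenyl for methyl on the ring nitrogen of compound 3

The source may hold more compounds than are shown below. What is called first, only, known or untested is meant among the compounds shown, and "the series" means these compounds.

Measured so far:
compound 1 `Cc1ccc(/C=C2\CN(C)CC3=C2N=C(S)NC3c2ccc(C)cc2)cc1` — 94000 nM
compound 2 `COc1ccc(/C=C2\CN(C)CC3=C2N=C(S)NC3c2ccc(OC)cc2)cc1` — 76400 nM
compound 3 `CN1C/C(=C\c2cccs2)C2=NN(C)C(c3cccs3)C2C1` — > 100000 nM

In a functional assay on cells (Ovarian cancer cell line, Homo sapiens) for inhibition (a higher number here means a weaker inhibitor of growth, a lower number a stronger inhibitor of growth), compound 1 gives 94000 nM. Compound 2 gives 76400 nM in this assay. For compound 3 the entry > 100000 nM is a limit of this assay and not a number. Compound 3 therefore stands at the limit of > 100000 nM in this assay, at which 1 of the 3 values shown sits, with no measured figure of its own, while compound 1 and compound 2 each have a measured figure that is well below that limit. Among the measured compounds shown here, no pair among the three measured compounds differs in a single place, so no measured step is available for this assay.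

Compound 4 `CN1C/C(=C\c2cccs2)C2=NN(c3ccccc3)C(c3cccs3)C2C1` is the next compound, not yet measured. It differs from compound 3 by phenyl in place of methyl on an amine nitrogen in a ring. For the measured compounds named here, nothing among the measured compounds tells how this assay answers a change at that position, and the only anchor is the limit for compound 3. The step of a number no higher from compound 3 to compound 4 (the limit leaves the size open) is therefore expected to be none beyond the usual scatter, in either direction. For compound 4 the estimate is 100000 nM, with a range from 40000 nM to 250000 nM, and a fair chance that this assay again reports only a limit.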

Compound 4, concentration for total growth inhibition: > 100000 nM
Compound 4 gave a limit, no number; the forecaster's own chance of this, stated with the estimate: 60%; the middle value lies on the limit itself.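

In this assay compound 3 and compound 4 each give only a limit and not a number, so no step can be read between them: the limit of > 100000 nM in this assay, at which 2 of the 4 values shown sit.

The compounds shown leave open whether phenyl in place of methyl on the amine nitrogen in a ring changes growth inhibition at all.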